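This account rests on a few compounds, and the source may have more. Where it says the series, first, only, none or still open, it means among the compounds named here.

This account follows a functional assay on B16 cells (Mus musculus) for cytotoxicity, read by CCK-8 assay, with a stated time of 24 h (on this read-out higher numbers stand for weaker inhibition and lower numbers for stronger inhibition), across a small set of aminochloropyrimidines sharing one core. Compound 1 `COc1cccc(-c2nc(N)c(Oc3ccccc3OC)c(Cl)n2)c1` gives 23600 nM in this assay. Compound 2 `COc1ccccc1Oc1c(N)nc(-c2cccc(Br)c2)nc1Cl` gives 24600 nM. Among the measured compounds shown here, the single measured step, a 1.0-fold higher number from compound 1 to compound 2 (0.02 log units; within the scatter), replaces a methoxy group on an aromatic carbon with bromo and leaves the read-out essentially unchanged. For the measured compounds named here, compound 1 thus has the lower of the two numbers, but since its only neighbour sits within the scatter, the two compounds stand level rather than in any order.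

Compound 3 `COc1ccccc1Oc1c(N)nc(-c2ccc(I)cc2)nc1Cl` has not yet been measured. It differs from compound 1 by 4-iodophenyl in place of 3-methoxyphenyl on an aromatic carbon. Going by the values given here, the one step that bears on this change is a 1.0-fold higher number from compound 1 to compound 2 (0.02 log units; within the scatter), which also exchanged the substituent on an aryl group attached to the core and produced nothing beyond the scatter. Among the compounds with values here, with only that step as a guide, the change to compound 3 is expected to give a step of a 1.0-fold higher number from compound 1 to compound 3 (0.01 log units; within the scatter), again not beyond the scatter. Compound 3 is therefore estimated at 24000 nM, in a range from 9000 nM to 60000 nM.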

Compound 3, half-maximal inhibitory concentration: 5400 nM
Beside the measured number, compound 3's estimate is 4.4-fold (0.65 log units) above it; the whole stated range lies above it.
By their numbers in this assay, from the lowest: compound 3; then compounds 1 and 2 (each within the scatter of the next).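

In this assay the aryl group on the carbon between two ring nitrogen atoms proves able to move the read-out: 4-iodophenyl in place of 3-methoxyphenyl gives a 4.4-fold lower number from compound 1 to compound 3 (0.64 log units; beyond the scatter), and 4-iodophenyl in place of 3-bromophenyl gives a 4.6-fold lower number from compound 2 to compound 3 (0.66 log units; beyond the scatter), whereas the exchange between the two 3-substituted phenyl groups stayed within the scatter. Both new steps are modest, and since compound 1 and compound 2 stand level, they record one separation: among these three compounds, only compound 3 stands apart, with the lower number. Nothing available gives a reason for this shift.

Each new step changes both the substituent and its location on the phenyl group, so the compounds shown leave open whether iodo or the 4-position carries the difference, a question that 3-iodophenyl and 4-bromophenyl would separate. They also leave open how far the trend runs at this position, for instance with 4-aminophenyl, 4-carboxyphenyl or a phenyl group bearing a longer chain.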